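Benzyl for methyl on the core: an expected gain

The source may report more compounds than this note shows. Statements on the series, on what has been measured and on what is new or still open speak of the compounds shown alone.

Measured compounds:
compound 1, `CCCN1CC(=O)N(CCC)c2ncn(C)c2C1=O`, > 250000 nM
compound 2, `CCN1CC(=O)N(CC)c2ncn(Cc3ccccc3)c2C1=O`, 16000 nM

In an assay for binding affinity to adenosine receptor A1 (Rattus norvegicus), read by radioligand binding (a higher number here means a weaker inhibitor, a lower number a stronger inhibitor), compound 1 reaches only a limit of the assay, > 250000 nM, so no number is known for it. Of the two values shown, one sits at the limit of > 250000 nM in this assay, at which 1 of the 2 values shown sits. Compound 2, with the shared core carrying a benzyl group, gives 16000 nM in this assay; it differs from compound 1 in more than one place, so its value is only a point of comparison.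

Compound 3, `CCCN1CC(=O)N(CCC)c2ncn(Cc3ccccc3)c2C1=O`, is not yet measured. It differs from compound 1 by phenyl in place of hydrogen on a saturated chain carbon bound to an aromatic nitrogen. For the measured compounds named here, no measured step covers this change. Since compound 1 sits at a limit, the step is expected to run toward stronger binding, with compound 3 giving a number rather than a limit, and the expected change is an at least 12-fold lower number from compound 1 to compound 3 (1.09 log units; beyond the scatter). Compound 3 is estimated at 20000 nM, within 5000 nM to 80000 nM.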

Compound 3, inhibition constant: 11000 nM
The estimate for compound 3 lay 1.8-fold (0.26 log units) above the measured number; measured number inside the range.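

In this assay, for the compounds shown here, the earlier compounds offered no pair that differed at this position alone. Phenyl in place of hydrogen on a saturated chain carbon bound to an aromatic nitrogen now gives an at least 22-fold lower number from compound 1 to compound 3 (1.35 log units; beyond the scatter), so this position does respond to the change, and a limit gives way to a number. The true size of the step cannot be read, only its lower bound, because compound 1 stands at a limit of the assay: the limit of > 250000 nM in this assay, at which 1 of the 3 values shown sits.

The compounds shown leave open whether the gain belongs to the phenyl ring as such, or whether a phenethyl group, a cyclohexylmethyl group or a pyridylmethyl group would serve as well or better. They also leave open how a hydroxyl group or a chlorine on the phenyl ring would read in this assay.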